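Swapping the Anilino Aryl Group in a Thiazolyl Chalcone

This account rests on a few compounds, and the source may have more. Where it says the series, first, only, none or still open, it means among the compounds named here.

compound 1 `COc1cc(/C=C/C(=O)c2sc(Nc3ccc(C)cc3)nc2C)cc(OC)c1OC` — > 25000 nM
compound 2 `Cc1nc(Nc2ccc(Cl)cc2)sc1C(=O)/C=C/c1ccc(Cl)cc1` — > 25000 nM

In a functional assay on BGC-823 cells (Homo sapiens) for cytotoxicity, read by MTT assay (a lower number here means a stronger inhibitor, a higher number a weaker inhibitor), compound 1 reaches only a limit of the measurement, > 25000 nM. Compound 2 likewise gives only a limit, > 25000 nM. Both known values sit at the limit of > 25000 nM in this assay, at which 2 of the 2 values shown sit, so compound 1 stands at the edge of what the measurement reports, with no number to compare. Compound 3 `COc1cc(/C=C/C(=O)c2sc(Nc3ccc(F)c(Cl)c3)nc2C)cc(OC)c1OC` differs from compound 1 in that (3-chloro-4-fluorophenyl in place of 4-methylphenyl on a nitrogen on an aromatic ring). For the measured compounds named here, with no measured step and both known compounds at the limit, the step from compound 1 to compound 3 is expected to be a step that the limit leaves unreadable from compound 1 to compound 3, most likely none beyond the scatter. Compound 3 is therefore expected to give 30000 nM, within 10000 nM to 100000 nM, probably again reported only as a limit.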

Compound 3, half-maximal inhibitory concentration: 9700 nM
The estimate for compound 3 lay 3.1-fold (0.49 log units) above the measured number, and the stated range ends above it.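

Changing 4-methylphenyl to 3-chloro-4-fluorophenyl on the nitrogen gives an at least 2.5-fold lower number from compound 1 to compound 3 (0.41 log units; beyond the scatter) in this assay, so this position can move the read-out. Compound 3 is the only compound here with a number rather than a limit, so the step has only a lower bound and its true size stays unknown: the limit of > 25000 nM in this assay, at which 2 of the 3 values shown sit.

On these data alone, whether the chlorine or the fluorine alone would give the same step remains open. So does the outcome with an amine or a carboxylic acid on this aromatic ring.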